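Hydroxylated replacement for an aryl group in a semicarbazide series

A few compounds are considered here, and "the series" means these few. Any claim that something is new, unique, unknown or untested is made for them only; others in the source may bear on it.

Compound 1 `COc1ccc(C(=NNC(=O)NNC(=O)NCCCC(C)Nc2cc(OC)cc3cccnc23)c2ccc(OC)cc2)cc1`: 82%
Compound 2 `COc1cc(NC(C)CCCNC(=O)NNC(=O)Nc2ccc(Cl)c(C(F)(F)F)c2)c2ncccc2c1`: 63%
Compound 3 `CCOC(=O)NC(c1ccccc1)c1ccc(Cl)cc1`: 21%

Of the compounds shown here, three have been measured in a physicochemical assay for inhibition, read by spectrophotometry, tested at 100 uM; on this read-out lower numbers stand for less inhibition and higher numbers for more inhibition at the one concentration tested (going by the name of the read-out). Compound 2 `COc1cc(NC(C)CCCNC(=O)NNC(=O)Nc2ccc(Cl)c(C(F)(F)F)c2)c2ncccc2c1` stands second highest of the three numbers. In this assay compound 1 gives 82%, a number higher than that of compound 2 by more than the usual scatter, while compound 3 gives 21%, well below compound 2 and also beyond the scatter. Compound 2 itself gives 63%.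

The unmeasured compound 4 `COc1cc(NC(C)CCCNC(=O)NNC(=O)NC(CO)(CO)CO)c2ncccc2c1` keeps the core of compound 2 and changes one end of the chain: 2-hydroxy-1,1-bis(hydroxymethyl)ethyl in place of 4-chloro-3-(trifluoromethyl)phenyl on an amide-type nitrogen. For the measured compounds named here, no pair of measured compounds differs in only one place, so no measured step tells what such an exchange does in this assay. The account therefore rests on the spread of the three numbers alone.

Because compound 3 gives 21%, the set shows that inhibition can fall well below the level of compound 2, and the exchange in compound 4 is expected to move the number downward, by a moderate step of a number 18 percentage points lower from compound 2 to compound 4 (beyond the scatter). Compound 4 is accordingly estimated at 45%, with a range from 20% to 70%.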

Compound 4, a percentage reported as inhibition, at one concentration (the size of the read-out at that concentration, not a potency): 49%
Estimate against measurement, compound 4: 4 percentage points below; low and high end bracket the measured number.
By their numbers in this assay, from the lowest: compound 3; then compound 4; then compound 2; then compound 1.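

For the compounds shown here, the exchange on the amide-type nitrogen gives the first readable step: in this assay the change from 4-chloro-3-(trifluoromethyl)phenyl to 2-hydroxy-1,1-bis(hydroxymethyl)ethyl gives a number 14 percentage points lower from compound 2 to compound 4 (beyond the scatter) in the number. The step is modest but beyond the scatter, so this position does register the exchange, while the aromatic ring with its chlorine and trifluoromethyl substituents proves not to be needed for a mid-range reading: compound 4, whose new group has no ring, still gives 49% at the one concentration tested. Nothing measured here explains why the number moves.

The exchange alters several things at once, removing the ring and the halogens while bringing in the three hydroxymethyl arms, and the compounds shown do not separate these contributions. An unsubstituted phenyl or a plain tert-butyl group on the same nitrogen would show how much of the step belongs to the ring and its substituents and how much to the hydroxymethyl arms.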